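The source may report more compounds than this note shows. Statements on the series, on what has been measured and on what is new or still open speak of the compounds shown alone.

Measured so far:
- compound 1 `ClCc1cccc(Cn2cnc3c(Cl)ncnc32)c1`: 41700 nM
- compound 2 `ClCc1ccc(Cn2cnc3nc(Cl)nc(Cl)c32)cc1`: 4070 nM
- compound 3 `ClCc1cccc(Cn2cnc3c(Cl)nc(Cl)nc32)c1`: 3540 nM

In a functional assay on OVCAR-8 cells (Homo sapiens) for cytotoxicity, read by sulforhodamine B assay, with a stated time of 48 h (a lower number here means a stronger inhibitor of growth, a higher number a weaker inhibitor of growth), compound 1 gives 41700 nM, compound 2 gives 4070 nM and compound 3 gives 3540 nM. Compound 2 and compound 3 lie within the scatter of each other; the difference between their two cores is not broken down here. From compound 3 to compound 1 the change is hydrogen in place of chloro on an aromatic carbon, and it made a 12-fold higher number from compound 3 to compound 1 (1.07 log units; beyond the scatter).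

Compound 4 `ClCc1ccc(Cn2cnc3ncnc(Cl)c32)cc1` is not yet measured. It arises from compound 2 by hydrogen in place of chloro on an aromatic carbon, the same change as from compound 3 to compound 1. Within the data shown here, the step is expected to be of similar size, an 11-fold higher number from compound 2 to compound 4 (1.04 log units; beyond the scatter), because a 12-fold higher number from compound 3 to compound 1 (1.07 log units; beyond the scatter) is the only precedent for this change in the set. For compound 4 the expected value in this assay is therefore 45000 nM, with a range from 15000 nM to 130000 nM.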

Compound 4, concentration for total growth inhibition: 11000 nM
Compound 4: the middle estimate sits 4.1-fold (0.61 log units) above what was measured; measured number outside the range, below it.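

In this assay, hydrogen in place of chloro gives a higher number on both cores, here a 2.7-fold higher number from compound 2 to compound 4 (0.43 log units; beyond the scatter), but the size of the step does not carry from one core to the other: the same change on two cores in this assay, a 12-fold higher number (1.07 log units; beyond the scatter) from compound 3 to compound 1 and a 2.7-fold higher number (0.43 log units; beyond the scatter) from compound 2 to compound 4, 4.4-fold (0.64 log units) apart, beyond the scatter of two such steps. The direction is shared by these two pairs, so a step measured on one core gives the direction on the other but not a reliable size. Two pairs do not show what in the core sets the size, nor whether the direction holds beyond these compounds.

The compounds shown carry only chloro or hydrogen at this place. From the compounds shown here alone, whether an amine or a methoxy group there would follow either step remains open.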